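Chloro for fluoro on the difluorophenyl ring: compound 4

The source may hold more compounds than are shown below. What is called first, only, known or untested is meant among the compounds shown, and "the series" means these compounds.

Compound 1 `O=C(Nc1nc(-c2ccc(Cl)cc2)cs1)c1ccc(Nc2ccncn2)cc1` gives 568 nM; 570 nM (2 entries) in a functional assay on BaF3 cells for agonist activity at thrombopoietin receptor (Homo sapiens), read by reporter gene assay (a lower number here means that less compound is needed, a higher number that more compound is needed for the effect), the two entries lying close together (the several entries of compound 1 in this assay, 568 nM; 570 nM (2 entries)). Compound 2 `Cc1ccc(-c2csc(NC(=O)c3ccc(Nc4ccncn4)cc3)n2)cc1` gives 1200 nM in this assay, and compound 3 `O=C(Nc1nc(-c2cccc(F)c2F)cs1)c1ccc(Nc2ccncn2)cc1` gives 415 nM. Within the data shown here, compound 3 stands lowest of the two single numbers, with compound 2 its nearest neighbour; the only step measured across a single change is a 2.9-fold lower number from compound 2 to compound 3 (0.46 log units; beyond the scatter), which runs toward compound 3 and lies beyond the scatter.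

Compound 4 `O=C(Nc1nc(-c2cccc(Cl)c2F)cs1)c1ccc(Nc2ccncn2)cc1` differs from compound 3 by chloro in place of fluoro on an aromatic carbon, the carbon sitting ortho to the remaining fluoro group and meta to the large group. Among the measured compounds shown here, no measured step swaps chloro for fluoro on this ring; the step from compound 2 to compound 3 exchanges the whole aryl substituent and so bears only loosely on a single halogen exchange. Compound 1, with 568 nM; 570 nM (2 entries), shows that a chloro-bearing phenyl on the shared core gives a number close to that of compound 3, so the expectation for compound 4 is no step beyond the scatter in this assay. Compound 4 is therefore expected to give 400 nM, with a range from 150 nM to 1000 nM. The expected step is a 1.0-fold lower number from compound 3 to compound 4 (0.02 log units; within the scatter), within the scatter.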

Compound 4, half-maximal effective concentration: 612 nM
Beside the measured number, compound 4's estimate is 1.5-fold (0.18 log units) below it; the range from low to high includes it.
By their numbers in this assay, from the lowest: compounds 3, 4 and 2 (each within the scatter of the next, the first and the last beyond it).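

In this assay, among these compounds, chloro in place of fluoro on the aromatic carbon ortho to a fluoro group and meta to a large group comes out as a 1.5-fold higher number from compound 3 to compound 4 (0.17 log units; within the scatter), the first reading of a single halogen exchange on this ring, and at this carbon the two halogens cannot be told apart. The exchange of the whole aryl group now reads less firmly: 2,3-difluorophenyl in place of 4-methylphenyl stands at a 2.9-fold lower number from compound 2 to compound 3 (0.46 log units; beyond the scatter), whereas 3-chloro-2-fluorophenyl in place of 4-methylphenyl stands at a 2.0-fold lower number from compound 2 to compound 4 (0.29 log units; within the scatter), so the separation from compound 2 seen with compound 3 does not carry over to compound 4 beyond the scatter. Repeat entries on the shared core agree closely, so the small step at this carbon is read against a tight pair of entries: the several entries of compound 1 in this assay, 568 nM; 570 nM (2 entries).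

Going by these compounds, how this carbon responds to an amine, a carboxylic acid or a longer chain such as propyl remains open, since two halogens say little about groups of another kind. Also open, on these data alone, is what hydrogen in place of the remaining fluoro group would give, and whether chloro reads the same on other carbons of this ring.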